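Removing the methyl group from compound 3

A few compounds are considered here, and "the series" means these few. Any claim that something is new, unique, unknown or untested is made for them only; others in the source may bear on it.

Measured compounds, all in a functional assay on the whole organism with Mus musculus as the target, in the rotarod test; a lower number here means that less compound is needed, a higher number that more compound is needed for the effect
Compound 1 (`O=C(/C=C1\CCc2ccccc21)NC1CC1`) gives 235 mg/kg
Compound 2 (`NC(=O)/C=C1\CCc2ccc(Cl)cc21`) gives 221 mg/kg
Compound 3 (`Cc1cccc2c1/C(=C/C(N)=O)CC2`) gives 56 mg/kg

Compound 3 has the lowest number of the three, and the gaps to compound 2 and compound 1 lie beyond the scatter. Compound 4 (`NC(=O)/C=C1\CCc2ccccc21`) has hydrogen in place of methyl on an aromatic carbon. For the measured compounds named here, no measured pair shows this change alone. Compound 2 lacks the methyl and gives 221 mg/kg while compound 1 also lacks it and gives 235 mg/kg in this assay as well, so a higher number is expected. The expected change is a 2.2-fold higher number from compound 3 to compound 4 (0.35 log units; beyond the scatter) and would lie slightly beyond the scatter. Compound 4 is estimated at 125 mg/kg in this assay with an expected range of 55 mg/kg to 290 mg/kg around it.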

Compound 4, dose for half-maximal effect: 164 mg/kg
Compound 4: middle estimate off by 1.3-fold (0.12 log units), on the low side, and the stated range covers the measured number.
By their numbers in this assay, from the lowest: compound 3; then compounds 4, 2 and 1 (each within the scatter of the next).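

In this assay, the methyl group on the aromatic carbon can now be read alone: a 2.9-fold higher number from compound 3 to compound 4 (0.47 log units; beyond the scatter), a modest step beyond the scatter. The two other single changes stay within the scatter, with a 1.3-fold lower number from compound 2 to compound 4 (0.13 log units; within the scatter) for chloro and a 1.4-fold lower number from compound 1 to compound 4 (0.16 log units; within the scatter) for cyclopropyl on the amide-type nitrogen, so among these steps only the loss of methyl separates a compound from compound 4. No measurement at hand accounts for the methyl step.

Going by these compounds, whether a larger group such as ethyl or methoxy on this same aromatic carbon would keep the lower number stays open. On these data alone, it is also open whether the methyl step would hold with cyclopropyl on the amide-type nitrogen.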